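The compounds below may be only part of what the source reports. "The series", "measured", "known", "first", "only" and "open" are said of these compounds alone.

In a functional assay on HeLa cells (Homo sapiens) for cytotoxicity, read by WST assay, with a stated time of 48 h (a lower number here means a stronger inhibitor, a higher number a weaker inhibitor), compound 1 `O[C@@H](c1ccccc1)[C@H]1CO[C@H](c2ccccc2)[C@@H](C/C=C/c2ccccc2)C1`, with phenyl on the double-bonded chain carbon, gives 6060 nM. Pyridin-2-yl at that place gives compound 2 `O[C@@H](c1ccccc1)[C@H]1CO[C@H](c2ccccc2)[C@@H](C/C=C/c2ccccn2)C1`, at 33800 nM. A hydroxy group on an aromatic carbon of that phenyl gives compound 3 `Oc1cccc(/C=C/C[C@H]2C[C@@H]([C@@H](O)c3ccccc3)CO[C@@H]2c2ccccc2)c1`, at 18600 nM. These changes amount to a 5.6-fold higher number from compound 1 to compound 2 (0.75 log units; beyond the scatter) and a 3.1-fold higher number from compound 1 to compound 3 (0.49 log units; beyond the scatter). Compound 3 therefore sits with compound 2 at the higher end of the numbers, the gap being a 1.8-fold lower number from compound 2 to compound 3 (0.26 log units; within the scatter).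

Compound 4 `O[C@@H](c1ccccc1)[C@H]1CO[C@H](c2ccccc2)[C@@H](C/C=C/c2ccccc2F)C1` keeps the shared core and differs from compound 3 at one place: 2-fluorophenyl in place of 3-hydroxyphenyl on a double-bonded chain carbon bound to a double-bonded chain carbon. Within the data shown here, no measured compound carries 2-fluorophenyl, so its own contribution is unknown. The closest guide is a 3.1-fold higher number from compound 1 to compound 3 (0.49 log units; beyond the scatter), since the hydroxy group now leaves, and only part of that size is expected to return. A modest move toward a lower number is expected, namely a 2.1-fold lower number from compound 3 to compound 4 (0.32 log units; beyond the scatter). For compound 4 the estimated value is 9000 nM, with an expected range of 4000 nM to 20000 nM.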

Compound 4, half-maximal inhibitory concentration: 9730 nM
Beside the measured number, compound 4's estimate is 1.1-fold (0.03 log units) below it, within the range that was stated.
By their numbers in this assay, from the lowest: compounds 1, 4, 3 and 2 (each within the scatter of the next, the first and the last beyond it).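

In this assay, a substituent on the phenyl need not shift the number beyond the scatter: fluoro in place of hydrogen on an aromatic carbon stays level with the unsubstituted ring (a 1.6-fold higher number from compound 1 to compound 4 (0.21 log units; within the scatter)), whereas the hydroxy group of compound 3 did move it. Yet 2-fluorophenyl also stays level with 3-hydroxyphenyl (a 1.9-fold lower number from compound 3 to compound 4 (0.28 log units; within the scatter)), and only pyridin-2-yl stands clearly apart from it (a 3.5-fold lower number from compound 2 to compound 4 (0.54 log units; beyond the scatter)). Nothing measured here explains how these groups differ in effect.

The compounds shown leave open how an amine or a carboxylic acid on that phenyl would read, and whether a longer chain carrying the ring would change the number. They also leave open whether any group at this place can fall clearly below compound 1, at 6060 nM.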